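A few compounds are considered here, and "the series" means these few. Any claim that something is new, unique, unknown or untested is made for them only; others in the source may bear on it.

Measured compounds:

Compound 1, `O=C(Nc1nnc(-c2ccc(Cl)cc2)s1)c1ccccc1`: in a functional assay on the whole organism (integument) for inhibition, with Chilo suppressalis as the target, read by scintillation counting, with a stated time of 72 h (a lower number here means a stronger inhibitor, a higher number a weaker inhibitor), compound 1 gives > 5010 nM.
Compound 2, `COc1ccccc1C(=O)Nc1nnc(-c2ccc(Cl)cc2)s1`: in this assay compound 2 gives 53.7 nM.

Going by the values given here, compound 2 stands as the only true number in this assay among the two values shown. The value for compound 1 is a limit of the assay rather than a number, as set out by the limit of > 5010 nM in this assay, at which 1 of the 2 values shown sits. Among the compounds with values here, the one measured step, an at least 93-fold lower number from compound 1 to compound 2 (1.96 log units; beyond the scatter), is large, showing that placing a methoxy group on the benzamide ring of the shared core moves the value a long way toward stronger inhibition.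

Compound 3, `CCOc1ccccc1C(=O)Nc1nnc(-c2ccc(Cl)cc2)s1`, takes this a little further. The change from compound 2 is methyl in place of hydrogen on a saturated chain carbon bound to an oxygen on an aromatic ring, so the methoxy becomes an ethoxy. Within the data shown here, no measured step bears directly on a methyl-to-ethyl change here; the step from compound 1 to compound 2 concerns the presence of the oxygen-bearing group, not its length. For that reason the expectation in this assay is a small step, within the usual scatter or only a little beyond it, with no firm direction. Compound 3 is therefore estimated at 80 nM, within a range of 20 nM to 400 nM. This estimate corresponds to an expected step of a 1.5-fold higher number from compound 2 to compound 3 (0.17 log units; within the scatter).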

Compound 3, half-maximal inhibitory concentration: > 5010 nM
Compound 3: a limit, no number; the forecaster's own chance of this, stated with the estimate: 5%; middle value at least 62-fold (1.79 log units) away from the limit.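

In this assay, going by these compounds alone, one added methyl turns methoxy into ethoxy and gives an at least 93-fold higher number from compound 2 to compound 3 (1.96 log units; beyond the scatter), so the substituent here is far less forgiving than the single earlier step could reveal. Compound 3 joins compound 1 at a limit of the assay, which is not a true number: the limit of > 5010 nM in this assay, at which 2 of the 3 values shown sit. The two limits leave the step from compound 1 to compound 3 unreadable, but among these three compounds only the methoxy group gives a true number, so an oxygen-bearing group at this place on the aromatic ring is not enough by itself.

Going by these compounds, the limit also leaves open how weak compound 3 really is, so the full size of the loss from methoxy to ethoxy remains unknown. The compounds shown cannot tell whether the sharp change depends on chain length alone, or whether a hydroxyl group, a fluorine atom or a longer chain such as propoxy at the same place would keep the strength of compound 2 or lose it as compound 3 does.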